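This account rests on a few compounds, and the source may have more. Where it says the series, first, only, none or still open, it means among the compounds named here.

In a functional assay on HepG2 cells (Homo sapiens) for antiproliferative activity, read by MTT assay, with a stated time of 24 h (on this read-out higher numbers stand for weaker inhibition and lower numbers for stronger inhibition), compound 2 (`C=CCc1cc(-c2ccccc2)ccc1O`) stands at > 100000 nM, a limit of the assay and not a number. Compound 3 (`C=CCc1cc(-c2ccc(F)cc2)ccc1O`) gives > 100000 nM, also a limit. Compound 1 (`C=CCc1cc(-c2cccc(C(F)(F)F)c2)ccc1O`), which also bears trifluoromethyl, gives 58300 nM. Compound 4 (`C=CCc1cc(-c2ccccc2C(F)(F)F)ccc1O`) differs from compound 2 by trifluoromethyl in place of hydrogen on an aromatic carbon, with trifluoromethyl in place of hydrogen on an aromatic carbon, ortho to a large group. The closest measured step, an at least 1.7-fold higher number from compound 1 to compound 2 (0.23 log units; that floor lies within the scatter), takes trifluoromethyl away, while the other, a step that the two limits leave unreadable from compound 2 to compound 3, adds fluoro. In this assay, therefore, only a small move toward lower numbers is expected, perhaps none beyond the scatter. The expected change is an at least 1.1-fold lower number from compound 2 to compound 4 (0.07 log units; that floor lies within the scatter). The estimate for compound 4 is 85000 nM, with an expected range from 40000 nM to 160000 nM.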

Compound 4, half-maximal inhibitory concentration: 52400 nM
Compound 4: the middle estimate sits 1.6-fold (0.21 log units) above what was measured, within the range that was stated.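

Trifluoromethyl ortho to a large group gives a number where the parent gives none in this assay, with an at least 1.9-fold lower number from compound 2 to compound 4 (0.28 log units; that floor lies within the scatter). Compound 4 gives 52400 nM and compound 1, with trifluoromethyl at another place on the same ring, gives 58300 nM, so the two placements shown cannot be told apart. The step stays only a floor because compound 2 is held at a limit and not a number: the limit of > 100000 nM in this assay, at which 2 of the 4 values shown sit.

The compounds shown leave open how an amine or a carboxylic acid at this position would read. They also leave open whether any change here could carry the number clearly beyond the scatter.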